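The source may hold more compounds than are shown below. What is called first, only, known or untested is meant among the compounds shown, and "the series" means these compounds.

Three compounds were measured in a functional assay on PC-3 cells (Homo sapiens) for inhibition, read by sulforhodamine B assay; a lower number here means a stronger inhibitor of growth, a higher number a weaker inhibitor of growth:

compound 1, `Cc1ccc2[nH]c(-c3ccc(-c4ccc(-c5cccc(Cl)c5)cc4)cc3)nc2c1`, giving 2670 nM
compound 2, `COc1ccc(-c2ccc(-c3ccc(-c4nc5cc(C)ccc5[nH]4)cc3)cc2)cc1OC`, giving 2560 nM
compound 3, `Oc1cccc2[nH]c(-c3ccc(-c4ccc(-c5cccc(Cl)c5)cc4)cc3)nc12`, giving 2560 nM

Compound 1 and compound 2 differ in one place, (3,4-dimethoxyphenyl in place of 3-chlorophenyl on an aromatic carbon), and this change gave a 1.0-fold lower number from compound 1 to compound 2 (0.02 log units; within the scatter). The unmeasured compound 4, `COc1ccc(-c2ccc(-c3ccc(-c4nc5c(O)cccc5[nH]4)cc3)cc2)cc1OC`, stands to compound 3 in the same way, the change being (3,4-dimethoxyphenyl in place of 3-chlorophenyl on an aromatic carbon), at the same place in the words given for both pairs. Compound 3 sits level with compound 2 at the digits given, and the difference between the core of compound 3 and that of compound 1 is not broken down here. Because the earlier occurrence of this change gave a 1.0-fold lower number from compound 1 to compound 2 (0.02 log units; within the scatter), compound 4 is expected to show a step of about a 1.0-fold lower number from compound 3 to compound 4 (0.01 log units; within the scatter) from compound 3 in this assay. Compound 4 is estimated at 2500 nM, with a likely range from 1200 nM to 5500 nM.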

Compound 4, concentration for 50% growth inhibition: 1240 nM
Beside the measured number, compound 4's estimate is 2.0-fold (0.30 log units) above it; measured number inside the range.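

In this assay, putting 3,4-dimethoxyphenyl in place of 3-chlorophenyl gave a 2.1-fold lower number from compound 3 to compound 4 (0.31 log units; beyond the scatter), and the two occurrences of this change do not differ measurably: the same change on two cores in this assay, a 1.0-fold lower number (0.02 log units; within the scatter) from compound 1 to compound 2 and a 2.1-fold lower number (0.31 log units; beyond the scatter) from compound 3 to compound 4, 2.0-fold (0.30 log units) apart, within the scatter of two such steps.
With 3,4-dimethoxyphenyl held in place, the difference in the core gave a 2.1-fold lower number from compound 2 to compound 4 (0.31 log units; beyond the scatter) on its own.
So the change carried across these two cores with no detectable difference in its effect, but two pairs cannot show that it would behave the same way on a third core.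

The compounds shown leave open what an amine or a carboxylic acid on that outer ring would do in this assay and whether the step would hold on other cores.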